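This account rests on a few compounds, and the source may have more. Where it says the series, first, only, none or still open, it means among the compounds named here.

Measured in a functional assay on a cell-free system (Platelet, plasma, Homo sapiens) for inhibition; a higher number here means a weaker inhibitor, a lower number a stronger inhibitor:
- compound 1 `O=C(NC[C@H](NS(=O)(=O)c1ccccc1)C(=O)O)c1ccc(N2CCC(NC3=NCCCN3)CC2)c(Cl)c1`: 90 nM
- compound 2 `O=C(NC[C@H](NS(=O)(=O)c1ccccc1)C(=O)O)c1ccc(N2CCC(NC3=NCCCN3)CC2)c(F)c1`: 37 nM
- compound 3 `COc1cc(C(=O)NC[C@H](NS(=O)(=O)c2ccccc2)C(=O)O)ccc1N1CCC(NC2=NCCCN2)CC1`: 130 nM

Two compounds share the upper end of this small set: a 1.4-fold higher number from compound 1 to compound 3 (0.16 log units; within the scatter), whereas a 3.5-fold higher number from compound 2 to compound 3 (0.55 log units; beyond the scatter). The unmeasured compound 4 `O=C(NC[C@H](NS(=O)(=O)c1ccccc1)C(=O)O)c1ccc(N2CCC(NC3=NCCCN3)CC2)c(O)c1` differs by hydrogen in place of methyl on an oxygen on an aromatic ring, which is hydrogen in place of methyl on an oxygen on an aromatic ring, or methoxy to hydroxy. Within the data shown here, no measured step makes this exact change. The closest evidence comes from swaps of the group on that same aromatic carbon, which range from the step above that stays within the scatter to the modest 2.4-fold lower number from compound 1 to compound 2 (0.39 log units; beyond the scatter). A small fall in the number is therefore expected, an estimated 1.9-fold lower number from compound 3 to compound 4 (0.27 log units; within the scatter). Compound 4 is estimated at 70 nM, with an expected range of 28 nM to 170 nM.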

Compound 4, half-maximal inhibitory concentration: 170 nM
For compound 4 the middle estimate is 2.4-fold (0.39 log units) below the measured one; low and high end bracket the measured number.
By their numbers in this assay, from the lowest: compound 2; then compounds 1, 3 and 4 (each within the scatter of the next).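

In this assay the change from methoxy to hydroxy gives a 1.3-fold higher number from compound 3 to compound 4 (0.12 log units; within the scatter) and the change from chloro to hydroxy gives a 1.9-fold higher number from compound 1 to compound 4 (0.28 log units; within the scatter), so hydroxy on this aromatic carbon cannot be told apart from either group. Fluoro does stand apart, with a 4.6-fold higher number from compound 2 to compound 4 (0.66 log units; beyond the scatter), and compound 2 remains the strongest inhibitor of the four. From the compounds shown here alone, what an amine or a nitrile on this same aromatic carbon would give stays open. Nothing shown here accounts for why fluoro alone stands apart.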